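The compounds below may be only part of what the source reports. "The series", "measured", "known", "first", "only" and "open" are said of these compounds alone.

Measured compounds:

Compound 1, `Cc1ccc2[nH]c(=O)c(CN(Cc3ccc(F)cc3)Cc3cccc4ccccc34)cc2c1`. In a toxicity assay on MDCK cells (Canis lupus familiaris) for cytotoxicity, read by crystal violet staining, with a stated time of 48 h (a lower number here means that less compound is tolerated, a higher number that more compound is tolerated), compound 1 gives > 5000 nM, which is a limit of the assay and not a number.
Compound 2, `CCc1ccc2[nH]c(=O)c(CN(Cc3ccc(F)cc3)Cc3cccc4ccccc34)cc2c1`. In this assay compound 2 gives > 5000 nM, again a limit rather than a number.
Compound 3, `CCc1ccc2[nH]c(=O)c(CN(Cc3ccc(C(C)(C)C)cc3)C(C)c3ccc(F)cc3)cc2c1`. In this assay, among the compounds with values here, compound 3 gives 2800 nM, the only number among the three.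

From compound 1 to compound 2 the change is methyl in place of hydrogen on a saturated chain carbon bound to an aromatic carbon. The step that the two limits leave unreadable from compound 1 to compound 2 cannot be read, because of the limit of > 5000 nM in this assay, at which 2 of the 3 values shown sit. How the core of compound 3 differs from that of compound 1 is not broken down here.

Compound 4, `CC(C)c1ccc2[nH]c(=O)c(CN(Cc3ccc(C(C)(C)C)cc3)C(C)c3ccc(F)cc3)cc2c1`, is not yet measured. It differs from compound 3 by methyl in place of hydrogen on a saturated chain carbon bound to an aromatic carbon and a saturated chain carbon. This is the same kind of change as from compound 1 to compound 2, but the place differs: there it sat on a saturated chain carbon bound to an aromatic carbon, here on a saturated chain carbon bound to an aromatic carbon and a saturated chain carbon. Since the earlier step gives no readable size, the expectation rests on compound 3 alone, with its value 2800 nM. A small step of a 1.1-fold higher number from compound 3 to compound 4 (0.03 log units; within the scatter) is expected. Compound 4 is estimated at 3000 nM, between 1400 nM and 6000 nM.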

Compound 4, half-maximal cytotoxic concentration: 13100 nM
Beside the measured number, compound 4's estimate is 4.4-fold (0.64 log units) below it; the whole stated range lies below it.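

In this assay, the change from ethyl to isopropyl gives a 4.7-fold higher number from compound 3 to compound 4 (0.67 log units; beyond the scatter), so on this core a single added methyl moves the number beyond the scatter. This is one readable case on one core, and it does not show that the same step would have the same size on another core, nor that its direction would carry over. The same kind of change on the core of compound 1, at a different place, cannot be read, so the two cores cannot be compared, because compound 1 and compound 2 both stand at a limit of the assay and not at a number: the limit of > 5000 nM in this assay, at which 2 of the 4 values shown sit.

The compounds shown leave open whether a longer chain such as propyl, a ring such as cyclopropyl, or a carboxylic acid at this place would continue the rise or reverse it. They also leave open what isopropyl would give on the core of compound 1.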